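This account rests on a few compounds, and the source may have more. Where it says the series, first, only, none or still open, it means among the compounds named here.

Working notes on the series. Three measured compounds share one core and differ only in the aryl group carried on the saturated chain carbon. In a functional assay on muscle tissue for agonist activity at histamine H2 receptor (Cavia porcellus) (a lower number here means a less potent compound, a higher number a more potent compound, by a factor of ten per unit of this negative logarithm), compound 1 `COc1ccc(C(CC/N=C(\N)NCCCc2c[nH]cn2)c2ccccn2)cc1` gives 7. Compound 2 `N=C(NCCCc1c[nH]cn1)NCCC(c1ccc(Cl)cc1)c1ccccn1` gives 7.39 in this assay, and compound 3 `N=C(NCCCc1c[nH]cn1)NCCC(c1ccc(C(F)(F)F)cc1)c1ccccn1` gives 7.23 in this assay. On these three numbers compound 3 stands in the middle, with compound 2 nearest and compound 1 furthest, and both gaps lie within the usual scatter. Within the data shown here, the one single-point step measured so far, a number 0.16 log units lower from compound 2 to compound 3 (within the scatter), is likewise within the scatter.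

Compound 4 `N=C(NCCCc1c[nH]cn1)NCCC(c1cc(F)cc(F)c1)c1ccccn1` has not yet been measured in this assay. The change is 3,5-difluorophenyl in place of 4-(trifluoromethyl)phenyl on a saturated chain carbon bound to an aromatic carbon and a saturated chain carbon. Among the measured compounds shown here, no measured step swaps exactly this pair of groups; the only step that bears on it is the exchange of one substituted phenyl for another, a number 0.16 log units lower from compound 2 to compound 3 (within the scatter), which stayed within the scatter, and the spread across compounds 1 to 3 is also narrow. The expected step in this assay is therefore a number 0.03 log units lower from compound 3 to compound 4 (within the scatter), nothing beyond the scatter. Compound 4 is estimated at 7.2 in this assay, with a range from 6.7 to 7.7.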

Compound 4, negative logarithm of the half-maximal effective concentration: 7.91
For compound 4 the middle estimate is 0.71 log units below the measured one, and the stated range ends below it.
By their numbers in this assay, from the lowest: compounds 1, 3 and 2 (each within the scatter of the next, the first and the last beyond it); then compound 4.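

In this assay, the saturated chain carbon bound to an aromatic carbon and a saturated chain carbon now shows that the choice of aryl group there can move the number beyond the scatter, which the earlier exchange of one substituted phenyl for another did not show. With 3,5-difluorophenyl in place of 4-(trifluoromethyl)phenyl the result is a number 0.68 log units higher from compound 3 to compound 4 (beyond the scatter), and with the same group in place of 4-chlorophenyl it is a number 0.52 log units higher from compound 2 to compound 4 (beyond the scatter), so the gain holds against both of these groups and does not rest on a single comparison. No measurement available here bears on what lies behind this gain.

The compounds shown carry 3,5-difluorophenyl as the only aryl group with this substitution, so the gain cannot yet be divided between the fluorine atoms themselves and the way they are arranged on the ring. Unsubstituted phenyl, a phenyl carrying a single fluorine and 3,5-dichlorophenyl at the same carbon would each help to separate these two readings, and how far the gain extends beyond this one group remains open.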